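Chloro to Bromo Repeated on a Second Core

The compounds below may be only part of what the source reports. "The series", "measured", "known", "first", "only" and "open" are said of these compounds alone.

Compound 1 `Clc1ccc(CSc2nnc(-c3cnccn3)o2)cc1` and compound 2 `Brc1ccc(CSc2nnc(-c3cnccn3)o2)cc1` share one core. In a functional assay on HeLa cells (Homo sapiens) for antiproliferative activity, read by MTT assay, with a stated time of 48 h (a higher number here means a weaker inhibitor, a lower number a stronger inhibitor), compound 1 gives 24600 nM, and compound 2 gives 21600 nM. The change between them, (bromo in place of chloro on an aromatic carbon), produced a 1.1-fold lower number from compound 1 to compound 2 (0.06 log units; within the scatter). Compound 3 `Clc1cccc(CSc2nnc(-c3cnccn3)n2-c2ccccc2)c1` is built on another core; how the two cores differ is not broken down here. In this assay compound 3 gives 13500 nM. Compound 4 `Brc1cccc(CSc2nnc(-c3cnccn3)n2-c2ccccc2)c1` is reached from compound 3 by bromo in place of chloro on an aromatic carbon, the same kind of change as before, though here the place is meta to a large group rather than para to a large group. From compound 3 to compound 4 a step of a 1.1-fold lower number from compound 3 to compound 4 (0.03 log units; within the scatter) is expected, resting on the earlier step of a 1.1-fold lower number from compound 1 to compound 2 (0.06 log units; within the scatter). Compound 4 is estimated at 12500 nM, between 6000 nM and 26000 nM.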

Compound 4, half-maximal inhibitory concentration: 9580 nM
The estimate for compound 4 lay 1.3-fold (0.12 log units) above the measured number; measured number inside the range.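

In this assay, bromo in place of chloro on an aromatic carbon gave a 1.4-fold lower number from compound 3 to compound 4 (0.15 log units; within the scatter) on the core of compound 3. Set beside the earlier step, the change reads alike on both cores: the same change on two cores in this assay, a 1.1-fold lower number (0.06 log units; within the scatter) from compound 1 to compound 2 and a 1.4-fold lower number (0.15 log units; within the scatter) from compound 3 to compound 4, 1.2-fold (0.09 log units) apart, within the scatter of two such steps

This shows that the exchange carried across the two cores without a difference that can be told apart, but each step lies within the scatter, so it does not show that bromo and chloro differ in this series, and two pairs alone establish no general rule.

The compounds shown leave open how other groups would behave at this place, such as an amine, a carboxylic acid or a methoxy group. They also leave open whether a change with a step beyond the scatter would carry across these cores.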